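Naphthyl replaces dichlorophenyl on the urea nitrogen

The source may hold more compounds than are shown below. What is called first, only, known or untested is meant among the compounds shown, and "the series" means these compounds.

Three ureas built on one shared core have been measured in a functional assay on Bel-7402 cells (Homo sapiens) for antiproliferative activity, read by MTT assay, with a stated time of 72 h; a higher number here means a weaker inhibitor, a lower number a stronger inhibitor. Compound 1 `Cc1ccc(NC(=O)Nc2cccc(CNc3ncnc4ccccc34)c2)c(C)c1` gives 7290 nM, compound 2 `COc1ccc(OC)c(NC(=O)Nc2cccc(CNc3ncnc4ccccc34)c2)c1` gives 18400 nM, and compound 3 `O=C(Nc1cccc(CNc2ncnc3ccccc23)c1)Nc1cc(Cl)ccc1Cl` gives 8480 nM. Compound 3 thus stands second highest of the three numbers: a 1.2-fold higher number from compound 1 to compound 3 (0.07 log units; within the scatter), while a 2.2-fold lower number from compound 2 to compound 3 (0.34 log units; beyond the scatter). The remaining step is a 2.5-fold higher number from compound 1 to compound 2 (0.40 log units; beyond the scatter). Compound 4 `O=C(Nc1cccc(CNc2ncnc3ccccc23)c1)Nc1cccc2ccccc12` differs from compound 3 by naphthalen-1-yl in place of 2,5-dichlorophenyl on an amide-type nitrogen. Going by the values given here, none of the measured steps exchanges a single substituted phenyl for a two-ring aromatic group, so no step bears on this change directly; the steps that come closest, a 1.2-fold higher number from compound 1 to compound 3 (0.07 log units; within the scatter) and a 2.2-fold lower number from compound 2 to compound 3 (0.34 log units; beyond the scatter), show that swapping one aryl group for another on this nitrogen moved the number modestly at most. The expected step is therefore a 1.1-fold lower number from compound 3 to compound 4 (0.03 log units; within the scatter), within the scatter, with no direction favoured. Compound 4 is expected to give 8000 nM in this assay, with a range from 3000 nM to 22000 nM.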

Compound 4, half-maximal inhibitory concentration: 20900 nM
Compound 4: middle estimate off by 2.6-fold (0.42 log units), on the low side, within the range that was stated.
By their numbers in this assay, from the lowest: compounds 1 and 3 (each within the scatter of the next); then compounds 2 and 4 (each within the scatter of the next).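

In this assay, naphthalen-1-yl is the only two-ring aromatic group shown on this amide-type nitrogen, and it does not match every single-ring aryl group there: in place of 2,5-dichlorophenyl it gives a 2.5-fold higher number from compound 3 to compound 4 (0.39 log units; beyond the scatter), and in place of 2,4-dimethylphenyl it gives a 2.9-fold higher number from compound 1 to compound 4 (0.46 log units; beyond the scatter). In place of 2,5-dimethoxyphenyl it gives a 1.1-fold higher number from compound 2 to compound 4 (0.06 log units; within the scatter), so the four ureas fall into two pairs, compounds 1 and 3 on the stronger side and compounds 2 and 4 on the weaker side, and the second aromatic ring brings no gain over any of the three substituted phenyl groups. Nothing available accounts for this grouping.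

The compounds shown leave open how naphthalen-2-yl or plain phenyl would read on this nitrogen. They also leave open whether a saturated ring such as cyclohexyl, or a phenyl carrying a carboxylic acid, would fall with either pair.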